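The compounds below may be only part of what the source reports. "The series", "measured", "known", "first", "only" and "open" are said of these compounds alone.

Three compounds have so far been measured in a functional assay on DU-145 cells (Homo sapiens) for inhibition, read by trypan blue exclusion, with a stated time of 96 h; on this read-out lower numbers stand for stronger inhibition of growth and higher numbers for weaker inhibition of growth:
compound 1 `O=C(/C(=C\c1csc([N+](=O)[O-])c1)S(=O)(=O)c1ccc(Br)cc1)c1ccc(Br)cc1` gives 1000 nM;
compound 2 `O=C(/C(=C\c1ccc(OC(F)(F)F)cc1)S(=O)(=O)c1ccc(Br)cc1)c1ccc(Br)cc1` gives 25000 nM;
compound 3 `O=C(/C(=C\c1ccc(Cl)cc1)S(=O)(=O)c1ccc(Br)cc1)c1ccc(Br)cc1` gives 50000 nM.

Among these three, compound 3 stands at the highest number, the weakest growth inhibition measured. Its nearest neighbour is compound 2: the step is a 2.0-fold higher number from compound 2 to compound 3 (0.30 log units; within the scatter), which lies within the scatter, so the two cannot be told apart on these data. Compound 1 lies far away: the step is a 50-fold higher number from compound 1 to compound 3 (1.70 log units; beyond the scatter), well beyond the scatter.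

The next compound, compound 4 `COc1ccc(/C=C(\C(=O)c2ccc(Br)cc2)S(=O)(=O)c2ccc(Br)cc2)c(OC)c1`, differs from compound 3 in one place: 2,4-dimethoxyphenyl in place of 4-chlorophenyl on a double-bonded chain carbon bound to a double-bonded chain carbon.

Going by the values given here, two measured steps bear on this change, both changing the same aryl group. The step of a 2.0-fold higher number from compound 2 to compound 3 (0.30 log units; within the scatter), swapping one substituent on that ring for another, stayed within the scatter. The step of a 50-fold higher number from compound 1 to compound 3 (1.70 log units; beyond the scatter), replacing the whole ring by a different one, was large. Replacing one six-membered carbon ring by another carrying two methoxy groups looks closer to the first kind of change, so the expectation in this assay is a small step, if any, tending toward a slightly lower number, and hardly beyond the scatter: a 1.7-fold lower number from compound 3 to compound 4 (0.22 log units; within the scatter).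

Compound 4 is therefore estimated at 30000 nM, with a range from 8000 nM to 100000 nM.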

Compound 4, concentration for 50% growth inhibition: 8000 nM
Compound 4: the middle estimate sits 3.8-fold (0.57 log units) above what was measured; low and high end bracket the measured number.
By their numbers in this assay, from the lowest: compound 1; then compound 4; then compounds 2 and 3 (each within the scatter of the next).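

In this assay, the group on this double-bonded chain carbon can shift growth inhibition beyond the scatter even when a six-membered aromatic carbon ring stays in place: 2,4-dimethoxyphenyl in place of 4-chlorophenyl gives the step (a 6.3-fold lower number from compound 3 to compound 4 (0.80 log units; beyond the scatter)). Going by these compounds alone, until now, the only change that kept such a ring was the swap of trifluoromethoxy for chloro (a 2.0-fold higher number from compound 2 to compound 3 (0.30 log units; within the scatter)), which stayed within the scatter, so this position looked insensitive to changes of that kind. Compound 4 still does not reach compound 1, however: the step from the 5-nitrothiophen-3-yl ring to 2,4-dimethoxyphenyl (an 8.0-fold higher number from compound 1 to compound 4 (0.90 log units; beyond the scatter)) is also beyond the scatter, which places compound 4 between compound 1 and compound 3 on this read-out.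

Nothing available here explains why these groups differ in this way. The compounds shown also leave open whether both methoxy groups are needed, and how a phenyl ring carrying a single methoxy group or an amine would compare at this position.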